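The source may report more compounds than this note shows. Statements on the series, on what has been measured and on what is new or still open speak of the compounds shown alone.

Measured so far:
compound 1 `C[C@@H](O[C@H]1CN2C(=O)C=C(c3ccc[n+]([O-])c3)CC2[C@@H]1c1ccc(F)cc1)c1cc(C(F)(F)F)cc(C(F)(F)F)c1`, in an assay on CHO cells for displacement of a labelled ligand from Substance-P receptor (Homo sapiens), in the presence of a further agent that is not named here (a higher number here means a weaker inhibitor, a lower number a stronger inhibitor), giving 2.3 nM
compound 2 `C[C@@H](O[C@H]1CN2C(=O)C=C(c3cnn(Cc4ccccc4)c3)CC2[C@@H]1c1ccc(F)cc1)c1cc(C(F)(F)F)cc(C(F)(F)F)c1`, in this assay giving 66 nM

Among the compounds with values here, compound 2 holds the highest number of the two, with compound 1 the nearest and the only comparator; the one step available, a 29-fold higher number from compound 1 to compound 2 (1.46 log units; beyond the scatter), is large. Compound 3 `C[C@@H](O[C@H]1CN2C(=O)C=C(C3=CCOCC3)CC2[C@@H]1c1ccc(F)cc1)c1cc(C(F)(F)F)cc(C(F)(F)F)c1` differs from compound 2 in that (a group of 6 heavy atoms (5 carbon, 1 oxygen; one six-membered non-aromatic ring with 1 hetero atom) in place of a group of 12 heavy atoms (10 carbon, 2 nitrogen; one five-membered aromatic ring with 2 hetero atoms, one six-membered aromatic ring of carbon only), on a double-bonded ring carbon). The same position carried the whole of the step from compound 1 to compound 2, where a small ring in place of the benzyl-pyrazole gave the lower number. Within the data shown here, the entering group is again small, so a move back towards compound 1 is expected in this assay, though no step between the two small groups exists here. Compound 3 is therefore estimated at 12 nM (range 3 nM to 50 nM), a step of a 5.5-fold lower number from compound 2 to compound 3 (0.74 log units; beyond the scatter).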

Compound 3, half-maximal inhibitory concentration: 9.6 nM
For compound 3 the middle estimate is 1.3-fold (0.10 log units) above the measured one; measured number inside the range.
By their numbers in this assay, from the lowest: compound 1; then compound 3; then compound 2.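

In this assay, a non-aromatic six-membered ring with one oxygen at the double-bonded ring carbon restores much of the potency lost with 1-benzyl-1H-pyrazol-4-yl, giving a 6.9-fold lower number from compound 2 to compound 3 (0.84 log units; beyond the scatter). An aromatic ring is thus not needed at this carbon for a low number, although the group of compound 1 still holds an edge, with a 4.2-fold higher number from compound 1 to compound 3 (0.62 log units; beyond the scatter). Nothing available explains either step. On these data alone, how an amine or a carboxylic acid on this ring would fare remains open. So does the contribution of the double bond in the entering ring, which a fully saturated tetrahydropyran-4-yl would address.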